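The compounds below may be only part of what the source reports. "The series", "measured", "known", "first", "only" and "open" are said of these compounds alone.

Measured compounds in a functional assay on HeLa cells (Homo sapiens) for cytotoxicity, read by MTT assay, with a stated time of 72 h; a higher number here means a weaker inhibitor, a lower number a stronger inhibitor:
- compound 1 `O=C(c1ccccc1F)N(/N=N/c1ccc([N+](=O)[O-])cc1Cl)c1ccc([N+](=O)[O-])cc1Cl`: 2350 nM
- compound 2 `O=C(c1ccc(C(F)(F)F)cc1)N(/N=N/c1ccc([N+](=O)[O-])cc1Cl)c1ccc([N+](=O)[O-])cc1Cl`: 1060 nM

Compound 2 gives the lower of the two numbers; the nearest is compound 1, separated by a 2.2-fold lower number from compound 1 to compound 2 (0.35 log units; beyond the scatter). Compound 3 `CC(=O)OCC(=O)N(/N=N/c1ccc([N+](=O)[O-])cc1Cl)c1ccc([N+](=O)[O-])cc1Cl` differs from compound 2 in one place: acetoxymethyl in place of 4-(trifluoromethyl)phenyl on a carbonyl carbon. Among the compounds with values here, the only measured step, a 2.2-fold lower number from compound 1 to compound 2 (0.35 log units; beyond the scatter), exchanged one six-membered aromatic ring for another on the same carbonyl carbon and was modest. Within the data shown here, no measured step removes the aromatic ring from that position altogether, so the step to compound 3 is not covered by the data; both aryl variants so far lie within a narrow band, and a non-aryl group is more likely to fall outside it. For compound 3 the expected step is a 3.3-fold higher number from compound 2 to compound 3 (0.52 log units; beyond the scatter), towards a higher number. The estimate for compound 3 in this assay is 3500 nM, within 1000 nM to 12000 nM.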

Compound 3, half-maximal inhibitory concentration: 350 nM
Compound 3: the middle estimate sits 10-fold (1.00 log units) above what was measured, outside the stated range (below it).
By their numbers in this assay, from the lowest: compound 3; then compound 2; then compound 1.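

In this assay the aromatic ring on the carbonyl carbon proves dispensable: acetoxymethyl, which has no ring, gives a 3.0-fold lower number from compound 2 to compound 3 (0.48 log units; beyond the scatter) and a 6.7-fold lower number from compound 1 to compound 3 (0.83 log units; beyond the scatter) and so places compound 3 lowest of the three compounds. The earlier aryl pair showed only a change from one aromatic ring to another, a 2.2-fold lower number from compound 1 to compound 2 (0.35 log units; beyond the scatter), and left open whether any aryl group was needed at this position. No supporting data bear on why the non-aryl group gives the lowest number.

Acetoxymethyl is the only non-aryl group here, so it remains open whether the lower number belongs to this group or to non-aryl groups generally; hydroxymethyl, plain methyl or a longer alkyl chain on the carbonyl carbon would separate the two. On these data alone, whether the same order holds in other cell lines also remains open.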